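This account rests on a few compounds, and the source may have more. Where it says the series, first, only, none or still open, it means among the compounds named here.

Working notes on the series

Measured in a functional assay (blood) for inhibition, with Homo sapiens as the target; a higher number here means a weaker inhibitor, a lower number a stronger inhibitor:
compound 1, `C/C(=N\OCCF)c1ccc(Sc2cc(F)cc(C3CCOCC3)c2)cc1`, gives 40 nM
compound 2, `CO[C@]1(c2cc(F)cc(S(=O)(=O)c3ccc(/C(C)=N/O)cc3)c2)CCO[C@@H](C)C1`, gives 20 nM
compound 3, `C/C(=N/O)c1ccc(COc2cc(F)cc(C3CCOCC3)c2)cc1`, gives 40 nM

Compound 1 stands level with compound 3 at the digits shown; the two together carry the highest numbers of the three. Compound 2 returns a number lower than that of compound 1, but the gap between them falls within the usual scatter of this assay, so no order can be drawn among the three on these figures alone.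

The next compound is compound 4, `C/C(=N\OC(C)C)c1ccc(Sc2cc(F)cc(C3CCOCC3)c2)cc1`. Relative to compound 1 it carries one alteration:

isopropyl in place of 2-fluoroethyl on an oxygen

For the measured compounds named here, no measured pair shows this alteration, so nothing tells how this assay answers an isopropyl in place of a 2-fluoroethyl on the oxygen. Both groups carry the same count of heavy atoms, neither adds a donor or an acceptor, and the rest of the structure is unchanged from compound 1. The step from compound 1 to compound 4 is therefore expected to stay within the scatter of this assay, with no clear direction, and the estimated move is a 1.1-fold higher number from compound 1 to compound 4 (0.05 log units; within the scatter). For compound 4 the estimated value is 45 nM, with a range from 15 nM to 130 nM.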

Compound 4, half-maximal inhibitory concentration: 920 nM
Estimate against measurement, compound 4: 20-fold (1.31 log units) below, and the stated range ends below it.
By their numbers in this assay, from the lowest: compounds 2, 1 and 3 (each within the scatter of the next); then compound 4.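

In this assay, for the compounds shown here, the group on an oxygen whose other neighbour is a double-bonded nitrogen turns out to matter: isopropyl in place of 2-fluoroethyl gives a 23-fold higher number from compound 1 to compound 4 (1.36 log units; beyond the scatter) and is the only readable step so far, well beyond the scatter. The two groups match in heavy-atom count and in hydrogen-bond donors and acceptors, and the rest of the structure is shared, so these counts do not separate compound 1 from compound 4, and the step belongs to the identity of the group alone. No measurement shown here gives a reason for the size of this step.

This single pair changes two things at once, the fluorine giving way to carbon and the unbranched chain giving way to a branched one, and an ethyl or a propyl group on the same oxygen would be needed to tell these two apart. Also open, from the compounds shown here alone, are how a longer chain or a 2-aminoethyl group at this oxygen would read, and whether the same step would appear on a core other than that of compound 1.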